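A few compounds are considered here, and "the series" means these few. Any claim that something is new, unique, unknown or untested is made for them only; others in the source may bear on it.

Measured compounds in a functional assay for agonist activity at G protein-coupled receptor 88 (Homo sapiens), read by HTRF and cAMP accumulation; a higher number here means that more compound is needed for the effect, a lower number that less compound is needed:
compound 1 `CC(C)C[C@H](N)CN(C(=O)C(C)Cc1ccccc1)c1ccc(-c2ccccc2)cc1`: 1.2 nM
compound 2 `CC[C@H](C)[C@H](N)CN(C(=O)[C@@H]1C[C@H]1c1ccccc1F)c1ccc(-c2ccccc2)cc1`: 650 nM

Of the two numbers, compound 2 gives the higher one; in this assay compound 2 stands a long way above compound 1, and the gap between them lies beyond the scatter of repeated measurements. Within the data shown here, no single-point step between measured compounds is available, so the two values can only be set side by side.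

Compound 3 `CC[C@H](C)[C@H](N)CN(C(=O)[C@@H]1C[C@H]1c1c(F)cccc1F)c1ccc(-c2ccccc2)cc1` is the next member to be examined. It differs from compound 2 in one place: fluoro in place of hydrogen on an aromatic carbon. Nothing in the measured set shows what fluoro in place of hydrogen on this ring does, so the step from compound 2 to compound 3 cannot be anchored to an observed one. The step of a 1.3-fold lower number from compound 2 to compound 3 (0.11 log units; within the scatter) is expected to stay within the usual scatter, with no clear direction. Compound 3 is therefore estimated at 500 nM, with a range from 150 nM to 1800 nM.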

Compound 3, half-maximal effective concentration: 11000 nM
The estimate for compound 3 lay 22-fold (1.34 log units) below the measured number; measured number outside the range, above it.
By their numbers in this assay, from the lowest: compound 1; then compound 2; then compound 3.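

In this assay the change from 2-fluorophenyl to 2,6-difluorophenyl gives a 17-fold higher number from compound 2 to compound 3 (1.23 log units; beyond the scatter) and marks this aromatic carbon, ortho to a large group, as a sensitive position in this series. A single fluoro in place of hydrogen, only one heavy atom, is enough to require clearly more compound for the effect. Nothing available here accounts for the size of this step.

Still open, going by these compounds, is whether this step is specific to fluoro or would also follow from a chloro, methyl or methoxy group on the same carbon. Also open, on these data alone, is what a plain phenyl, with no fluoro on the ring, would give on the same cyclopropyl scaffold, and so whether the first fluoro has any effect of its own.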